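Series notes: cyclopropylamino to piperidin-1-yl at the shared core

The source may report more compounds than this note shows. Statements on the series, on what has been measured and on what is new or still open speak of the compounds shown alone.

Measured so far in a functional assay on PC-3 cells (Homo sapiens) for inhibition, with a stated time of 72 h; on this read-out lower numbers stand for stronger inhibition and higher numbers for weaker inhibition:
compound 1 `COc1ccc(NC(=O)Nc2nc(Sc3c[nH]c4ccccc34)cc(N3CCN(c4ccccn4)CC3)n2)cc1` gives 33400 nM
compound 2 `O=C(Nc1ccccc1)Nc1nc(NC2CC2)cc(Sc2c[nH]c3ccccc23)n1` gives 17500 nM
compound 3 `Cc1cc(Cl)ccc1NC(=O)Nc1nc(NC2CC2)cc(Sc2c[nH]c3ccccc23)n1` gives 11100 nM

Compound 2 sits between the other two numbers. Its nearest neighbour is compound 3, reached by a 1.6-fold lower number from compound 2 to compound 3 (0.20 log units; within the scatter) with 4-chloro-2-methylphenyl in place of phenyl on an amide-type nitrogen. The gap from compound 2 to compound 1 is also within the scatter, so the three numbers are not separated.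

Compound 4 `O=C(Nc1ccccc1)Nc1nc(Sc2c[nH]c3ccccc23)cc(N2CCCCC2)n1` is not yet measured. It differs from compound 2 by piperidin-1-yl in place of cyclopropylamino on an aromatic carbon. Among the compounds with values here, no measured step touches this aromatic carbon: the only step measured, from compound 2 to compound 3, is at the amide-type nitrogen and lies within the scatter, so it does not bear directly on the present change. Compound 1 carries a different group at the same aromatic carbon together with a different group on the amide-type nitrogen, so its number cannot be split between the two changes. With nothing beyond the scatter anywhere among the three, the expected step from compound 2 to compound 4 is a 1.1-fold higher number from compound 2 to compound 4 (0.06 log units; within the scatter), none beyond the scatter. Compound 4 is therefore expected to give 20000 nM, with a range from 7000 nM to 60000 nM.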

Compound 4, half-maximal inhibitory concentration: 12100 nM
Beside the measured number, compound 4's estimate is 1.7-fold (0.22 log units) above it; measured number inside the range.
By their numbers in this assay, from the lowest: compounds 3, 4, 2 and 1 (each within the scatter of the next, the first and the last beyond it).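

Within the data shown here, this is the first single change read at the aromatic carbon next to the ring nitrogen. In this assay, a 1.4-fold lower number from compound 2 to compound 4 (0.16 log units; within the scatter), so for this pair, piperidin-1-yl with 0 hydrogen-bond donors in place of cyclopropylamino with 1 leaves the two compounds unseparated, and the larger ring does not separate them either. The reading holds only with phenyl on the amide-type nitrogen, and nothing available explains it.

From the compounds shown here alone, it remains open whether a group of another kind at this carbon, such as morpholin-4-yl, a primary amine or a longer alkylamino chain, would give a step beyond the scatter. Also open, going by these compounds, is whether piperidin-1-yl behaves the same way with 4-chloro-2-methylphenyl on the amide-type nitrogen.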